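Notes on compound 4 against three measured analogues

A few compounds are considered here, and "the series" means these few. Any claim that something is new, unique, unknown or untested is made for them only; others in the source may bear on it.

Measured in a functional assay on cells for agonist activity at Free fatty acid receptor 1 (Homo sapiens), read by FLIPR and calcium flux; a higher number here means that more compound is needed for the effect, a lower number that less compound is needed:
compound 1 `CC#C[C@@H](Cc1nnn[nH]1)c1ccc(OCc2ccc3scc(-c4cccnc4C)c3c2)cc1`: 88 nM
compound 2 `CC#C[C@@H](Cc1nnn[nH]1)c1ccc(OCc2cc(Cl)c3scc(-c4ccccc4C)c3c2)cc1`: 63 nM
compound 3 `CC#C[C@@H](Cc1nnn[nH]1)c1ccc(OCc2ccc3scc(-c4ccc(OCCC(C)(C)O)cc4C)c3c2)cc1`: 8 nM

Compound 1 gives the highest number of the three, though compound 2 differs from it by less than the scatter, so the two cannot be separated. Compound 3 gives a number well below that of compound 1, beyond the scatter.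

Compound 4 `CC#C[C@@H](Cc1nnn[nH]1)c1ccc(OCc2ccc3scc(-c4cncnc4C)c3c2)cc1` differs from compound 1 by 4-methylpyrimidin-5-yl in place of 2-methylpyridin-3-yl on an aromatic carbon. For the measured compounds named here, no pair of measured compounds differs in this way, so no measured step covers the change; the nearest guide is the shared core, which all four carry. The step from compound 1 to compound 4 in this assay is expected to be a 1.3-fold higher number from compound 1 to compound 4 (0.10 log units; within the scatter), not beyond the scatter in either direction. Compound 4 is estimated at 110 nM, with a range of 40 nM to 300 nM.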

Compound 4, half-maximal effective concentration: 37 nM
Beside the measured number, compound 4's estimate is 3.0-fold (0.47 log units) above it; measured number below the stated range.
By their numbers in this assay, from the lowest: compound 3; then compounds 4, 2 and 1 (each within the scatter of the next, the first and the last beyond it).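

In this assay, on an aromatic carbon two ring bonds from the ring sulfur, 4-methylpyrimidin-5-yl in place of 2-methylpyridin-3-yl gives a 2.4-fold lower number from compound 1 to compound 4 (0.38 log units; beyond the scatter) in a step that is modest in size. For the compounds shown here, this is the first single-place comparison, and it shows that this position accepts a six-membered aromatic ring with 2 hetero atoms with no loss in this read-out.

As far as these compounds go, whether an amine on the 4-methylpyrimidin-5-yl ring would extend the step remains open. Nothing measured here explains the step.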